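Swapping a Hydroxymethyl for a Phenoxy Group

The source may hold more compounds than are shown below. What is called first, only, known or untested is meant among the compounds shown, and "the series" means these compounds.

Measured so far:
- Compound 1, `O=C1C(Nc2ccc(CO)cc2)=CC(=O)c2ncncc21`: 5700 nM
- Compound 2, `COc1cccc(NC2=CC(=O)c3ncncc3C2=O)c1`: 1800 nM

Both compounds share the same core and differ only in the substituted aniline attached to it. In a functional assay on BXPC-3 cells (Homo sapiens) for cytotoxicity, read by MTT assay, with a stated time of 72 h (a lower number here means a stronger inhibitor, a higher number a weaker inhibitor), compound 1 gives 5700 nM, the higher of the two numbers. Compound 2, which carries a methoxy group instead, gives 1800 nM; the gap between the two lies beyond the usual scatter, so compound 1 stands as the weaker of the pair on the numbers in hand.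

The next compound, compound 3, `O=C1C(Nc2ccc(Oc3ccccc3)cc2)=CC(=O)c2ncncc21`, is not yet measured. It is built from compound 1 by a single change: phenoxy in place of hydroxymethyl on an aromatic carbon. For the measured compounds named here, no directly comparable step is available among the measured compounds, so the size of the effect is open. A modest shift toward a lower number in this assay is expected for compound 3, but not one that clearly exceeds the scatter. The expected step from compound 1 to compound 3 is a 2.0-fold lower number from compound 1 to compound 3 (0.31 log units; beyond the scatter). For compound 3 the estimate is 2800 nM, with a range from 900 nM to 9000 nM.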

Compound 3, half-maximal inhibitory concentration: 3600 nM
Estimate against measurement, compound 3: 1.3-fold (0.11 log units) below; measured number inside the range.
By their numbers in this assay, from the lowest: compounds 2, 3 and 1 (each within the scatter of the next, the first and the last beyond it).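

Replacing hydroxymethyl with phenoxy on this aromatic carbon, para to a large group, gives a 1.6-fold lower number from compound 1 to compound 3 (0.20 log units; within the scatter) in this assay, so the two compounds cannot be told apart in this assay. For the compounds shown here, this is the first view of how much size this position can take without a step beyond the scatter: the group grows from 2 heavy atoms to 7, gains a six-membered aromatic ring and gives up its hydrogen-bond donor, yet the numbers for compound 1 and compound 3 stay within the scatter of each other. No measurement here bears on why such a large swap leaves the result within the scatter.

The ring and the lost hydrogen-bond donor arrive together in this single swap, so their separate contributions cannot be read from these compounds, and they might be cancelling each other or might both count for little. An amine or a carboxylic acid on the same aromatic carbon would show whether this position stays as undemanding with groups of a different kind, or whether the range seen so far holds only for neutral groups built from carbon, hydrogen and oxygen.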